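The compounds below may be only part of what the source reports. "The series", "measured", "known", "first", "only" and "open" are said of these compounds alone.

For the measured compounds named here, in a functional assay on cells (Homo sapiens) for inhibition (on this read-out higher numbers stand for weaker inhibition of growth and lower numbers for stronger inhibition of growth), compound 1 `C=C/C=C\[C@H](C)[C@H](OC(N)=O)[C@@H](C)[C@H](O)CC/C=C\C(C)[C@@H](O)[C@@H](C)/C=C\CC[C@@H]1O[C@@H](OC)[C@H](C)[C@@H](OCOC)[C@@H]1C` gives 3.4 nM, the only exact number so far. Compound 2 `CC1=C(O)O[C@@H](CC/C=C\[C@H](C)[C@H](O)C(C)/C=C\CC[C@@H](O)[C@H](C)[C@@H](OC(N)=O)C(C)C)[C@H](C)C1=O` is reported only as a limit, > 50 nM. Compound 3 `CCCCCC(C)(C)[C@H](OC(N)=O)[C@@H](C)[C@H](O)CC/C=C\C(C)[C@@H](O)[C@@H](C)/C=C\CC[C@@H]1O[C@@H](OC)[C@H](C)[C@@H](OCOC)[C@@H]1C` keeps the core of compound 1 and alters one chain end: a group of 8 heavy atoms (8 carbon; no ring) in place of a group of 6 heavy atoms (6 carbon; no ring), on a saturated chain carbon bound to an oxygen next to a carbonyl group and a saturated chain carbon. Going by the values given here, no measured pair shows what such a swap does, so any forecast here is a judgement. The expected change is a clear weakening of growth inhibition, beyond the usual scatter, estimated as a 15-fold higher number from compound 1 to compound 3 (1.17 log units; beyond the scatter). In this assay the expected value for compound 3 is 50 nM, with an estimated range from 10 nM to 300 nM.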

Compound 3, concentration for 50% growth inhibition: 23 nM
Compound 3: middle estimate off by 2.2-fold (0.34 log units), on the high side; the range from low to high includes it.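

In this assay, the chain end on this saturated chain carbon proves to matter: exchanging the 1-methylpenta-2,4-dien-1-yl group for a group of 8 heavy atoms gives a 6.8-fold higher number from compound 1 to compound 3 (0.83 log units; beyond the scatter). Growth inhibition weakens but is not lost, as compound 3 still gives a measured 23 nM. Nothing measured here points to a cause for this change. This single swap cannot separate the removal of the double bonds from the change in chain size. From the compounds shown here alone, how a chain end carrying an amine or a phenyl ring would behave at this place stays open.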